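A few compounds are considered here, and "the series" means these few. Any claim that something is new, unique, unknown or untested is made for them only; others in the source may bear on it.

Compound 1 `O=C(NO)c1cnc(N2C[C@@H]3CN(S(=O)(=O)c4cc(C(F)(F)F)cc(C(F)(F)F)c4)C[C@@H]3C2)nc1`: 1700 nM
Compound 2 `O=C(NO)c1cnc(N2C[C@@H]3CN(S(=O)(=O)c4ccc(OC(F)(F)F)cc4)C[C@@H]3C2)nc1`: 530 nM
Compound 3 `O=C(NO)c1cnc(N2C[C@H]3CN(Cc4cc(Cl)cc(Cl)c4)C[C@H]3C2)nc1`: 530 nM

In a functional assay on HCT-116 cells (Homo sapiens) for inhibition, read by sulforhodamine B assay, with a stated time of 72 h (a higher number here means a weaker inhibitor of growth, a lower number a stronger inhibitor of growth), compound 3 gives 530 nM. This is level with compound 2, and together they hold the lowest number of the three, while compound 1 lies higher, beyond the scatter. Compound 4 `COc1ccc(CN2C[C@@H]3CN(c4ncc(C(=O)NO)cn4)C[C@@H]3C2)cc1` carries 4-methoxyphenyl in place of 3,5-dichlorophenyl on a saturated chain carbon bound to an amine nitrogen in a ring. Going by the values given here, no measured pair shows what such a swap does, so no step beyond the scatter is expected in this assay, in either direction. The estimated change is a 1.0-fold higher number from compound 3 to compound 4 (0.02 log units; within the scatter). The estimate for compound 4 is 550 nM, with an expected range of 180 nM to 1700 nM.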

Compound 4, concentration for 50% growth inhibition: 900 nM
Beside the measured number, compound 4's estimate is 1.6-fold (0.21 log units) below it; measured number inside the range.
By their numbers in this assay, from the lowest: compounds 2, 3, 4 and 1 (each within the scatter of the next, the first and the last beyond it).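

Across this assay, replacing 3,5-dichlorobenzyl with 4-methoxybenzyl gives a 1.7-fold higher number from compound 3 to compound 4 (0.23 log units; within the scatter), the only step between compounds that differ in one place. On a saturated chain carbon bound to an amine nitrogen in a ring, then, this swap of the aromatic group leaves the number within the scatter, even though the chlorine atoms are lost. No measurement shown explains this result. Still open, as far as these compounds go, is what a carboxylic acid or an amine on that aromatic ring would do. From the compounds shown here alone, a longer chain between the ring and the amine nitrogen also remains untested here.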